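From acetyl to benzoyl on a shared core

The compounds below may be only part of what the source reports. "The series", "measured", "known", "first", "only" and "open" are said of these compounds alone.

Values in a functional assay on Bel-7402 cells (Homo sapiens) for inhibition, read by MTT assay; on this read-out higher numbers stand for weaker inhibition and lower numbers for stronger inhibition:
Compound 1 `C=C1C(=O)[C@@]23C(=O)OC[C@]4([C@@H](OC(C)=O)CCC(C)(C)[C@H]4C=O)[C@@H]2CC[C@H]1[C@H]3OC(=O)c1ccc(Cl)cc1`: 1510 nM
Compound 2 `C=C1C(=O)[C@@]23C(=O)OC[C@]4([C@@H](OC(C)=O)CCC(C)(C)[C@H]4C=O)[C@@H]2CC[C@H]1[C@H]3OC(=O)c1ccc(OC)cc1`: 2470 nM
Compound 3 `C=C1C(=O)[C@@]23C(=O)OC[C@]4([C@@H](OC(C)=O)CCC(C)(C)[C@H]4C=O)[C@@H]2CC[C@H]1[C@H]3OC(C)=O`: 3960 nM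

Compound 3 gives 3960 nM, a number within the scatter of compound 2 and beyond the scatter from compound 1, which has the lower number. Compound 4 `C=C1C(=O)[C@@]23C(=O)OC[C@]4([C@@H](OC(C)=O)CCC(C)(C)[C@H]4C=O)[C@@H]2CC[C@H]1[C@H]3OC(=O)c1ccccc1` has not yet been measured. It carries phenyl in place of methyl on a carbonyl carbon, acetyl to benzoyl (phenyl in place of methyl on a carbonyl carbon). Among the measured compounds shown here, two measured steps bear on this change when read in reverse, since each puts methyl where an aromatic group stood: a 2.6-fold higher number from compound 1 to compound 3 (0.42 log units; beyond the scatter) and a 1.6-fold higher number from compound 2 to compound 3 (0.20 log units; within the scatter). The substituent on the aromatic ring matters little in these data, with a 1.6-fold higher number from compound 1 to compound 2 (0.21 log units; within the scatter). A small move to a lower number in this assay is therefore expected, and it may not clear the scatter. The estimated move is a 1.7-fold lower number from compound 3 to compound 4 (0.24 log units; within the scatter). The estimate for compound 4 is 2300 nM, with an expected range of 1200 nM to 4000 nM.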

Compound 4, half-maximal inhibitory concentration: 3050 nM
Beside the measured number, compound 4's estimate is 1.3-fold (0.12 log units) below it, within the range that was stated.
By their numbers in this assay, from the lowest: compounds 1, 2, 4 and 3 (each within the scatter of the next, the first and the last beyond it).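

In this assay, phenyl in place of methyl on this carbonyl carbon gives a 1.3-fold lower number from compound 3 to compound 4 (0.11 log units; within the scatter) and so does not by itself separate benzoyl from acetyl. The ring substituents now read differently: hydrogen in place of methoxy gives a 1.2-fold higher number from compound 2 to compound 4 (0.09 log units; within the scatter), while hydrogen in place of chloro gives a 2.0-fold higher number from compound 1 to compound 4 (0.31 log units; beyond the scatter), so among these benzoates only the chloro compound, compound 1, stands apart from the unsubstituted ring. No evidence at hand explains these numbers.

The compounds shown leave open whether the separation of compound 1 is particular to chloro or would also appear with fluoro, bromo or an amine on the ring. They also leave open how a longer chain, such as propanoyl or butanoyl, would compare with acetyl and benzoyl on this carbonyl carbon.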